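A few compounds are considered here, and "the series" means these few. Any claim that something is new, unique, unknown or untested is made for them only; others in the source may bear on it.

Measured so far in a functional assay on BMDM cells (Mus musculus, strain C57BL/6) for inhibition, with a stated time of 2 days; a lower number here means a stronger inhibitor, a higher number a weaker inhibitor:

compound 1 `CCOC(=O)c1sc(NC(=O)Cn2cc(-c3cccs3)nn2)nc1C`: 20 nM
compound 2 `CCOC(=O)c1sc(NC(=O)Cn2cc(-c3ccc(F)cc3)nn2)nc1C`: 660 nM
compound 3 `Cc1csc(NC(=O)Cn2cc(-c3ccc(Cl)cc3)nn2)n1`: 520 nM

Compound 3 stands second highest of the three numbers, close to compound 2 and far from compound 1, which has the lowest number. Compound 4 `CCOC(=O)c1sc(NC(=O)Cn2cc(-c3ccc(Cl)cc3)nn2)nc1C` differs from compound 3 by ethoxycarbonyl in place of hydrogen on an aromatic carbon. Among the measured compounds shown here, the only measured step, a 33-fold higher number from compound 1 to compound 2 (1.52 log units; beyond the scatter), concerns the aryl group on the triazole and does not touch the position changed here. For the measured compounds named here, compounds 2 and 3 differ in both the ester and the halogen, and their two values lie within the scatter of each other, so the ester alone has no separate step. For compound 4 no step beyond the scatter is expected, a 1.0-fold lower number from compound 3 to compound 4 (0.02 log units; within the scatter). The estimate for compound 4 in this assay is 500 nM, range 200 nM to 1500 nM.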

Compound 4, half-maximal inhibitory concentration: 180 nM
Beside the measured number, compound 4's estimate is 2.8-fold (0.44 log units) above it; measured number below the stated range.
By their numbers in this assay, from the lowest: compound 1; then compound 4; then compounds 3 and 2 (each within the scatter of the next).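

In this assay, among the compounds shown here, ethoxycarbonyl on the aromatic carbon next to the ring sulfur now has a step of its own (a 2.9-fold lower number from compound 3 to compound 4 (0.46 log units; beyond the scatter)), which no earlier pair could show. With the ester held constant, the halogen also matters (a 3.7-fold lower number from compound 2 to compound 4 (0.56 log units; beyond the scatter)), a difference the values of compound 2 and compound 3 did not reveal, and thiophen-2-yl keeps a clear lead over 4-chlorophenyl (a 9.0-fold higher number from compound 1 to compound 4 (0.95 log units; beyond the scatter)). Nothing measured here accounts for these steps. Open, on these data alone, is whether a carboxylic acid or an amide at this position would match the ethyl ester. Also open, as far as these compounds go, is whether the ester step holds with thiophen-2-yl in place of 4-chlorophenyl.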